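A few compounds are considered here, and "the series" means these few. Any claim that something is new, unique, unknown or untested is made for them only; others in the source may bear on it.

Compound 1 `COc1ccc(F)cc1CNCCCNc1ccnc2cc(Cc3ccc(C#N)cc3)ccc12` sits among three compounds measured in a physicochemical assay for solubility, with a stated time of 18 h, at pH 7.4 (a lower number here means a less soluble compound, a higher number a more soluble compound), where compound 1 gives 4200 nM. Compound 3 `COc1cccc(CNCCCNc2ccnc3cc(Cc4ccc(C#N)cc4)ccc23)c1O` gives 4200 nM, and the step of no change at the digits printed from compound 1 to compound 3 (within the scatter) shows the two level. Compound 2 `FC(F)(F)c1ccc(-c2ccc3c(NCCCNCc4ccco4)ccnc3c2)cc1` gives 32000 nM, the highest of the three.

Compound 4 `COc1ccc(F)cc1CNCCCNc1ccnc2cc(Oc3ccc(Cl)cc3)ccc12` differs from compound 1 at the core: 4-chlorophenoxy in place of 4-cyanobenzyl on an aromatic carbon. Within the data shown here, no measured step changes this part of the core alone; the one measured step, no change at the digits printed from compound 1 to compound 3 (within the scatter), alters a different group and leaves the number unchanged. Compound 2 carries another group at this position but also a different amine tail, so its number cannot be read as a single step.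

Without a guiding step, compound 4 is expected near compound 1, a step of a 1.4-fold lower number from compound 1 to compound 4 (0.15 log units; within the scatter) within the scatter. Compound 4 is therefore estimated at 3000 nM, between 800 nM and 12000 nM.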

Compound 4, solubility: 14500 nM
The estimate for compound 4 lay 4.8-fold (0.68 log units) below the measured number; the measured number lies above the stated range.
By their numbers in this assay, from the lowest: compounds 1 and 3 (each within the scatter of the next); then compound 4; then compound 2.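

At this aromatic carbon of the shared core, 4-chlorophenoxy in place of 4-cyanobenzyl gives a 3.5-fold higher number from compound 1 to compound 4 (0.54 log units; beyond the scatter) in this assay, a step beyond the scatter. With the amine tail held constant, this is the first single change shown that moves the number, as the step from compound 1 to compound 3 did not. No measurement here explains the rise.

The link to the ring and the group on that ring change together, and the compounds shown cannot separate the two. Going by these compounds, how a carboxylic acid or an amine on this carbon would read also remains open.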